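The source may report more compounds than this note shows. Statements on the series, on what has been measured and on what is new or still open speak of the compounds shown alone.

Measured compounds in the series:

- compound 1, `COC(=O)c1cccc2c(C(=O)c3ccccc3)cc(C(=O)c3ccc(C(F)(F)F)cc3)c-2c1`: in an assay on cells for displacement of a labelled ligand from Orexin receptor type 2 (Homo sapiens), read by scintillation counting, with stated times of 10 min and 90 min, tested at 10 uM (on this read-out lower numbers stand for less inhibition and higher numbers for more inhibition at the one concentration tested (going by the name of the read-out)), compound 1 gives 27%
- compound 2, `O=C(O)c1cccc2c(C(=O)c3ccccc3)cc(C(=O)c3ccc(C(F)(F)F)cc3)c-2c1`: in this assay compound 2 gives 26.4%
- compound 3, `CCOc1ccc(-c2cc(C(=O)c3ccccc3)c3ccc(C(=O)OC)ccc2-3)cc1`: in this assay compound 3 gives 19.1%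

Compound 1 and compound 2 share a core and differ in one place: hydrogen in place of methyl on an oxygen next to a carbonyl group. The step that this change made in this assay is a number 0.6 percentage points lower from compound 1 to compound 2 (within the scatter), so within this pair the methoxycarbonyl and the carboxy compound give numbers that cannot be told apart. Compound 3 carries a different core from compound 1; the difference between the two cores is not broken down here. Its own number in this assay stands within the scatter of both compound 1 and compound 2.

Compound 4, `CCOc1ccc(-c2cc(C(=O)c3ccccc3)c3ccc(C(=O)O)ccc2-3)cc1`, is not yet measured. It relates to compound 3 as compound 2 relates to compound 1: hydrogen in place of methyl on an oxygen next to a carbonyl group. The place of the change reads the same in both pairs, so this is the same change made on the second core.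

Going by the values given here, the only guide to what it will do is the measured pair, where the step was small. For compound 4 the step from compound 3 is expected to be a number 0.6 percentage points lower from compound 3 to compound 4 (within the scatter), resting on compound 1 and compound 2 and their step of a number 0.6 percentage points lower from compound 1 to compound 2 (within the scatter) in this assay. Compound 4 is therefore expected to give about 18.5% in this assay, with a range from 8% to 30%.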

Compound 4, a percentage reported as inhibition, at one concentration (the size of the read-out at that concentration, not a potency): -16.9%
For compound 4 the middle estimate is 35.4 percentage points above the measured one; the measured number lies below the stated range.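

Hydrogen in place of methyl on an oxygen next to a carbonyl group does not make the same step on the two cores in this assay: the same change on two cores in this assay, a number 0.6 percentage points lower (within the scatter) from compound 1 to compound 2 and a number 36 percentage points lower (beyond the scatter) from compound 3 to compound 4, 35.4 percentage points apart, beyond the scatter of two such steps

On the core of compound 3 the change is a number 36 percentage points lower from compound 3 to compound 4 (beyond the scatter), and in this assay compound 4 gives -16.9%, so the near-absent step on the core of compound 1 cannot be carried over to this second core as a working estimate. Going by these compounds alone, with one pair on each core, this shows only that the step differs between these two cores; it does not show which part of the cores goes with the difference, nor how the same change would behave on any third core.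

Open, as far as these compounds go, is whether the ethoxy group, the trifluoromethyl group or the different arrangement of the two cores is what separates the two steps, which only compounds differing from these in one place could settle. Also open, from the compounds shown here alone, is how other groups in place of the carboxy group, such as an amide, a hydroxymethyl group or a longer ester like the ethyl ester, would read on each core in this assay.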